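Removing One Fluoro from Compound 1: What to Expect

The source may report more compounds than this note shows. Statements on the series, on what has been measured and on what is new or still open speak of the compounds shown alone.

Two compounds have so far been measured in a functional assay on the whole organism with Mus musculus as the target; on this read-out higher numbers stand for an effect only at larger amounts of compound and lower numbers for an effect already at smaller amounts:
- compound 1 `CCN(C)C(=O)/C=C1\CCc2c(F)cc(F)cc21`: 56 mg/kg
- compound 2 `CN(C)C(=O)/C=C1\CCc2c(F)cc(F)cc21`: 50 mg/kg

Among the measured compounds shown here, compound 1 stands with the higher of the two numbers, but its only neighbour is compound 2, and the step of a 1.1-fold lower number from compound 1 to compound 2 (0.05 log units; within the scatter) lies within the scatter, so the two cannot be told apart. That step puts hydrogen in place of methyl on a saturated chain carbon bound to an amide-type nitrogen.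

Compound 3 `CCN(C)C(=O)/C=C1\CCc2ccc(F)cc21` has not yet been measured. It differs from compound 1 in one place: hydrogen in place of fluoro on an aromatic carbon. For the measured compounds named here, no measured step touches a fluoro group or an aromatic carbon; the single step seen so far concerns the carbon bound to the amide-type nitrogen, and it was within the scatter. As far as these compounds go, nothing in the data therefore points to a change in either direction in this assay, and the expectation rests on the value of compound 1 alone, with a wider range to reflect that this change is untested. For compound 3 the expected step is a 1.1-fold higher number from compound 1 to compound 3 (0.03 log units; within the scatter). Compound 3 is accordingly estimated at 60 mg/kg, within a range from 28 mg/kg to 130 mg/kg.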

Compound 3, dose for half-maximal effect: 100 mg/kg
The estimate for compound 3 lay 1.7-fold (0.22 log units) below the measured number; measured number inside the range.
By their numbers in this assay, from the lowest: compounds 2, 1 and 3 (each within the scatter of the next).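

Among the compounds shown here, this is the first change to the aromatic part of the core: in this assay, hydrogen in place of fluoro on an aromatic carbon, ortho to a fused ring and meta to a fluoro group, gives a 1.8-fold higher number from compound 1 to compound 3 (0.25 log units; within the scatter). Like a 1.1-fold lower number from compound 1 to compound 2 (0.05 log units; within the scatter), this step lies within the scatter, so neither the change on the chain at the amide-type nitrogen nor the loss of this fluoro group yields a difference that repeated measurements could be expected to separate. Nothing measured on these compounds speaks to why the numbers fall where they do.

Still open, as far as these compounds go, is whether a chloro, methoxy or nitrile group on the same aromatic carbon would move the number beyond the scatter, and whether hydrogen in place of the remaining fluoro group would do so. For the compounds shown here, equally open is whether the exchange of this fluoro group for hydrogen would give a similar step if made on compound 2, since only one such pair is available so far.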